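Chain Lengthening Before an Unmeasured Hexokinase Assay Result

This account rests on a few compounds, and the source may have more. Where it says the series, first, only, none or still open, it means among the compounds named here.

Compound 1, `Nc1ncnc2c1nc(NCCCCNC(=O)CI)n2[C@@H]1O[C@H](COP(=O)(O)OP(=O)(O)OP(=O)(O)O)[C@@H](O)[C@H]1O`, in an assay on isolated protein for inhibition of hexokinase-1 (Rattus norvegicus), with a stated time of 6 h, tested at 10 mM (a lower number here means less inhibition, a higher number more inhibition at the concentration tested (going by the name of the read-out)), gives 0%.
Compound 2, `O=C(CI)NCCCCC(=O)NCCCCCCNc1ncnc2c1ncn2[C@@H]1O[C@H](COP(=O)(O)OP(=O)(O)OP(=O)(O)O)[C@@H](O)[C@H]1O`, in this assay gives 0%.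
Compound 3, `O=C(CI)NCCC(=O)NCCCCCCNc1ncnc2c1ncn2[C@@H]1O[C@H](COP(=O)(O)OP(=O)(O)OP(=O)(O)O)[C@@H](O)[C@H]1O`, in this assay gives 0%.

Compounds 2 and 3 share a core; compound 1 rests on another, and the difference between the two cores is not broken down here. Within the pair, compound 2 arises from compound 3 by 2-(((iodomethyl)carbonyl)amino)ethyl in place of ((iodomethyl)carbonyl)amino on a saturated chain carbon, two bonds along the chain from a carbonyl carbon, and the step of no change at the digits printed from compound 3 to compound 2 (within the scatter) stayed within the scatter. Compound 4, `Nc1ncnc2c1nc(NCCCCCCNC(=O)CI)n2[C@@H]1O[C@H](COP(=O)(O)OP(=O)(O)OP(=O)(O)O)[C@@H](O)[C@H]1O`, is not yet measured in this assay. It arises from compound 1 by 2-(((iodomethyl)carbonyl)amino)ethyl in place of ((iodomethyl)carbonyl)amino on a saturated chain carbon, four bonds along the chain from a nitrogen on an aromatic ring. This is the same kind of change, not the same: in compound 3 it sits on a saturated chain carbon, two bonds along the chain from a carbonyl carbon; in compound 1, on a saturated chain carbon, four bonds along the chain from a nitrogen on an aromatic ring. Within the data shown here, all three measured values sit level, and the one measured step was flat. On that, compound 4 is expected to make a step of no change at the digits printed from compound 1 to compound 4 (within the scatter) in this assay. The estimate for compound 4 is 0%, expected to fall between 0% and 10%.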

Compound 4, a percentage reported as inhibition, at one concentration (the size of the read-out at that concentration, not a potency): 0%
Estimate against measurement, compound 4: no gap at the digits printed, and the stated range covers the measured number.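

Replacing ((iodomethyl)carbonyl)amino with 2-(((iodomethyl)carbonyl)amino)ethyl on the core of compound 1 gives no change at the digits printed from compound 1 to compound 4 (within the scatter) in this assay. Set beside the earlier step on the other core, the same change reads alike on both cores: the same change on two cores in this assay, no change at the digits printed (within the scatter) from compound 3 to compound 2 and no change at the digits printed (within the scatter) from compound 1 to compound 4, 0 percentage points apart, within the scatter of two such steps This agreement shows only that the change brought out no inhibition on either core, since compound 4 gives 0% like the other three; it does not show how the change would carry over on a compound with measurable inhibition.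

The compounds shown leave open whether a longer chain would give any inhibition in this assay. The same question stands for an amine or a carboxylic acid in place of ((iodomethyl)carbonyl)amino.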